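Pyridyl isomers on the shared core: cytotoxicity notes

The compounds below may be only part of what the source reports. "The series", "measured", "known", "first", "only" and "open" are said of these compounds alone.

Compound 3 `O=[N+]([O-])c1ccc(C2=NOC(c3ccc(-c4ccncc4)cc3)C2)o1` is read in an ADME assay on HeLa cells (Homo sapiens) for cytotoxicity, read by MTT assay, with a stated time of 96 h (on this read-out higher numbers stand for weaker inhibition and lower numbers for stronger inhibition), where compound 3 gives > 50000 nM, a limit of the assay rather than a number. Compound 2 `O=[N+]([O-])c1ccc(C2=NOC(c3ccc(-c4cccnc4)cc3)C2)o1` gives > 50000 nM, also a limit. Compound 1 `O=[N+]([O-])c1ccc(C2=NOC(c3ccc(N4CCN(Cc5ccccn5)CC4)cc3)C2)o1` gives > 50000 nM, again a limit. The step that the two limits leave unreadable from compound 2 to compound 3 stays unreadable because of the limit of > 50000 nM in this assay, at which 3 of the 3 values shown sit. Compound 4 `O=[N+]([O-])c1ccc(C2=NOC(c3ccc(-c4ccccn4)cc3)C2)o1` differs from compound 3 by pyridin-2-yl in place of pyridin-4-yl on an aromatic carbon. Going by the values given here, the only measured step that bears on this change is the one between the two pyridyl isomers, and its size is hidden by the limit. No step beyond the scatter is therefore expected in this assay. Compound 4 is expected to sit at the limit as well, estimated at 80000 nM with a range of 30000 nM to 300000 nM. The expected step that the limit leaves unreadable from compound 3 to compound 4 is none beyond the scatter.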

Compound 4, half-maximal inhibitory concentration: > 50000 nM
Compound 4: no number, only a limit (the forecaster's own chance of this, stated with the estimate: 90%); the middle value lies beyond the limit too.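

No step can be read from compound 3 to compound 4 or from compound 2 to compound 4, because the values give only a limit: the limit of > 50000 nM in this assay, at which 4 of the 4 values shown sit.

The compounds shown leave open whether the pyridin-2-yl, pyridin-3-yl and pyridin-4-yl isomers differ at all.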